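This account rests on a few compounds, and the source may have more. Where it says the series, first, only, none or still open, it means among the compounds named here.

Within the data shown here, compound 2 `[O-][S+](Cc1cc(Br)cs1)C(c1ccccc1)c1ccccc1` gives 13700 nM in an assay on HEK293 cells for inhibition of sodium-dependent dopamine transporter (Homo sapiens), read by scintillation counting, with stated times of 5 min and 1 min (a lower number here means a stronger inhibitor, a higher number a weaker inhibitor), the lowest of the two numbers measured so far; compound 1 `Cc1noc(C[S+]([O-])C(c2ccccc2)c2ccccc2)n1` gives 56700 nM. Among the measured compounds shown here, the one measured step, a 4.1-fold lower number from compound 1 to compound 2 (0.62 log units; beyond the scatter), is the only one bearing on the next change. Compound 3 `[O-][S+](Cc1cc(C2CC2)on1)C(c1ccccc1)c1ccccc1` differs from compound 2 by 5-cyclopropyl-1,2-oxazol-3-yl in place of 4-bromothiophen-2-yl on a saturated chain carbon bound to a sulfur, so a five-membered aromatic ring with 2 hetero atoms again sits on the saturated chain carbon bound to a sulfur, as in compound 1. Because a 4.1-fold lower number from compound 1 to compound 2 (0.62 log units; beyond the scatter) was modest, the step to compound 3 is expected to run the other way, estimated at a 2.2-fold higher number from compound 2 to compound 3 (0.34 log units; beyond the scatter). Compound 3 is therefore estimated at 30000 nM, within a range of 10000 nM to 90000 nM.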

Compound 3, half-maximal inhibitory concentration: 38600 nM
The estimate for compound 3 lay 1.3-fold (0.11 log units) below the measured number; low and high end bracket the measured number.
By their numbers in this assay, from the lowest: compound 2; then compounds 3 and 1 (each within the scatter of the next).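

On a saturated chain carbon bound to a sulfur, 5-cyclopropyl-1,2-oxazol-3-yl does not match 4-bromothiophen-2-yl in this assay, with a 2.8-fold higher number from compound 2 to compound 3 (0.45 log units; beyond the scatter). Replacing 3-methyl-1,2,4-oxadiazol-5-yl with 5-cyclopropyl-1,2-oxazol-3-yl gives a 1.5-fold lower number from compound 1 to compound 3 (0.17 log units; within the scatter), so these two groups are not separated, and among the three compounds only compound 2 stands apart. No independent measurement bears on the reason for this. Still open, as far as these compounds go, is whether the bromine or the thiophene ring accounts for the position of compound 2, and how an unsubstituted phenyl or an amine would read at this place.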